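Weak antiproliferative chalcones: chloro to methyl swap

This account rests on a few compounds, and the source may have more. Where it says the series, first, only, none or still open, it means among the compounds named here.

Measured so far:
Compound 1 `COc1cc(-c2cc(C(=O)/C=C/c3ccc(Cl)cc3)nc3cc(-c4ccccc4)nn23)cc(OC)c1OC` — 53900 nM
Compound 2 `COc1ccc(-c2cc(C(=O)/C=C/c3ccc(Cl)cc3)nc3cc(-c4ccccc4)nn23)cc1OC` — 39100 nM

In an ADME assay on HEK293 cells (Homo sapiens) for antiproliferative activity, read by MTT assay, with a stated time of 24 h (a lower number here means a stronger inhibitor, a higher number a weaker inhibitor), compound 1 gives 53900 nM, the higher of the two numbers recorded; compound 2 sits close to it, and the step of a 1.4-fold lower number from compound 1 to compound 2 (0.14 log units; within the scatter) does not separate them. Both compounds are weak inhibitors in this assay.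

Compound 3 `COc1cc(-c2cc(C(=O)/C=C/c3ccc(C)cc3)nc3cc(-c4ccccc4)nn23)cc(OC)c1OC` is the next member. It differs from compound 1 by methyl in place of chloro on an aromatic carbon. Among the compounds with values here, no measured pair shows this chloro-to-methyl exchange; the only step known, a 1.4-fold lower number from compound 1 to compound 2 (0.14 log units; within the scatter), concerns a methoxy elsewhere on the shared core and cannot be carried over to the present change. What the two measurements do show is that a single-group alteration on this core has so far left the number inside the scatter. With nothing pointing in either direction, the step from compound 1 to compound 3 in this assay is expected to stay within the scatter, as a 1.1-fold lower number from compound 1 to compound 3 (0.03 log units; within the scatter). For compound 3 the value in this assay is estimated at 50000 nM, with a range from 20000 nM to 125000 nM.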

Compound 3, half-maximal inhibitory concentration: 56100 nM
Beside the measured number, compound 3's estimate is 1.1-fold (0.05 log units) below it; the measured number falls inside the stated range.
By their numbers in this assay, from the lowest: compounds 2, 1 and 3 (each within the scatter of the next).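

In this assay the exchange of chloro for methyl, on the aromatic carbon para to a large group, gives a 1.0-fold higher number from compound 1 to compound 3 (0.02 log units; within the scatter), so 4-methylphenyl and 4-chlorophenyl cannot be told apart at this position. Within the data shown here, this is the first reading at this end of the molecule: the earlier step, a 1.4-fold lower number from compound 1 to compound 2 (0.14 log units; within the scatter), concerned a methoxy elsewhere on the shared core, and now single-group changes at two separate places have both stayed inside the scatter, with all three compounds remaining weak inhibitors. No supporting data bear on why this exchange leaves the number where it is.

Chloro and methyl are the only two groups read at this position, so it remains open whether a carboxylic acid or a dimethylamino group there would carry the number beyond the scatter. Also open, on these data alone, is whether any change to the (2-(4-chlorophenyl)ethenyl)carbonyl unit as a whole, such as replacing the ethenyl link with a saturated ethyl chain, would separate a compound from compound 1 in this assay at all.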